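Compound 3 and a weak cytotoxicity reading

The compounds below may be only part of what the source reports. "The series", "measured", "known", "first", "only" and "open" are said of these compounds alone.

Measured in a functional assay on MCF7 cells (Homo sapiens) for cytotoxicity, read by MTT assay, with a stated time of 72 h; on this read-out lower numbers stand for stronger inhibition and higher numbers for weaker inhibition:
Compound 1 `Cn1ccc2c(Oc3ccc(NC(=O)c4cc5cccnc5n(-c5ccc(C(F)(F)F)cc5Cl)c4=O)cc3F)ncnc21`: "not active" (no number reported)
Compound 2 `O=C(Nc1ccc(Oc2ncnc3[nH]ccc23)c(F)c1)c1cc2cccnc2n(-c2ccc(Br)cc2)c1=O`: 27000 nM

Going by the values given here, compound 2 holds the only number in this small set, at 27000 nM, since compound 1 was reported without one. The step followed here leads from compound 2 to compound 3 `O=C(Nc1ccc(Oc2ncnc3[nH]ccc23)c(F)c1)c1cc2cccnc2n(-c2ccc(C(F)(F)F)cc2Cl)c1=O`, which has not yet been measured. In this step, 2-chloro-4-(trifluoromethyl)phenyl takes the place of 4-bromophenyl on an aromatic nitrogen (2-chloro-4-(trifluoromethyl)phenyl in place of 4-bromophenyl on an aromatic nitrogen). Among the compounds with values here, no pair of measured compounds differs in one place, so the data offer no direct gauge of such an exchange. In this assay, no change beyond the usual scatter is therefore expected, and no direction is favoured. The expected change is a 1.1-fold lower number from compound 2 to compound 3 (0.03 log units; within the scatter). A result without a number also remains possible, as compound 1 showed with "not active" (no number reported). For compound 3, the estimated value is 25000 nM, with an expected range from 8000 nM to 70000 nM.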

Compound 3, half-maximal inhibitory concentration: 214000 nM
Beside the measured number, compound 3's estimate is 8.6-fold (0.93 log units) below it; measured number outside the range, above it.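

In this assay the exchange of 4-bromophenyl for 2-chloro-4-(trifluoromethyl)phenyl on the aromatic nitrogen gives a 7.9-fold higher number from compound 2 to compound 3 (0.90 log units; beyond the scatter) and so lies beyond the usual scatter. Going by these compounds alone, this is the first direct gauge of any change in this small set, and it shows that the number at this position responds to the group carried there, moving toward weaker inhibition even though the starting reading was already weak. No measurement shown here accounts for the shift, so its cause stays unassigned.

The step alters several things at once, as the entering group adds both a chlorine and a trifluoromethyl group while losing the bromine, so the compounds shown cannot say which part carries the change, and a plain 4-(trifluoromethyl)phenyl or 2-chlorophenyl group, or an amine on that ring, remains an open comparison. Compound 1 carries the same 2-chloro-4-(trifluoromethyl)phenyl group and gives "not active" (no number reported) in this assay without a number, so it offers no measured value to set against compound 3.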